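The source may report more compounds than this note shows. Statements on the series, on what has been measured and on what is new or still open speak of the compounds shown alone.

Measured so far:
compound 1 `ClCCCSc1nc2cc(Cl)ccc2[nH]1` — 24100 nM
compound 2 `CN1CCN(CCCSc2nc3ccccc3[nH]2)CC1` — 77900 nM

In a functional assay on MCF7 cells (Homo sapiens) for cytotoxicity, read by MTT assay, with a stated time of 24 h (a higher number here means a weaker inhibitor, a lower number a stronger inhibitor), compound 2 gives the higher of the two numbers, and the gap to compound 1 lies beyond the usual scatter. Compound 3 `CN1CCN(CCCSc2nc3cc(Cl)ccc3[nH]2)CC1` differs from compound 2 by one change: chloro in place of hydrogen on an aromatic carbon. Within the data shown here, no pair of measured compounds shows this change on its own, so no step in this assay can be read for it. The step is expected to be small, within or close to the scatter, as a 1.6-fold lower number from compound 2 to compound 3 (0.19 log units; within the scatter). Compound 3 is therefore estimated at 50000 nM, in the range from 20000 nM to 120000 nM.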

Compound 3, half-maximal inhibitory concentration: 13900 nM
Compound 3: the middle estimate sits 3.6-fold (0.56 log units) above what was measured; measured number outside the range, below it.
By their numbers in this assay, from the lowest: compounds 3 and 1 (each within the scatter of the next); then compound 2.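

In this assay, chloro in place of hydrogen on an aromatic carbon can now be read on its own, and it gives a 5.6-fold lower number from compound 2 to compound 3 (0.75 log units; beyond the scatter), so this ring position responds clearly to the change. With that ring chloro kept, 4-methylpiperazin-1-yl in place of chloro on the saturated chain gives a 1.7-fold lower number from compound 1 to compound 3 (0.24 log units; within the scatter), so swapping the chain end shows no clear effect in this pair. Nothing measured here explains why the ring chloro matters. Going by these compounds, whether bromo or methoxy on the same carbon would act like chloro stays open, as does the effect of a longer chain leading to the 4-methylpiperazin-1-yl group.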